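Phenyl ester variation on the chromone acyloxy series

This account rests on a few compounds, and the source may have more. Where it says the series, first, only, none or still open, it means among the compounds named here.

Measured compounds:
compound 1 `COC(=O)c1cc(F)ccc1OC(=O)COc1cc(O)c2c(=O)cc(-c3ccccc3)oc2c1`: 6820 nM
compound 2 `COC(=O)c1ccc(Cl)cc1OC(=O)COc1cc(O)c2c(=O)cc(-c3ccccc3)oc2c1`: 12400 nM
compound 3 `COC(=O)c1cccc(Cl)c1OC(=O)COc1cc(O)c2c(=O)cc(-c3ccccc3)oc2c1`: 38700 nM

All three share a core and differ only in the aryl group on the oxygen next to the carbonyl group, and all were run in a functional assay on cells (T-cell, Mus musculus, strain BALB/c) for inhibition, read by MTT assay, with a stated time of 72 h; on this read-out higher numbers stand for weaker inhibition and lower numbers for stronger inhibition. Compound 2 sits second highest of the three numbers; its nearest neighbour is compound 1 with a 1.8-fold higher number from compound 1 to compound 2 (0.26 log units; within the scatter), and its furthest is compound 3 with a 3.1-fold higher number from compound 2 to compound 3 (0.49 log units; beyond the scatter). Compound 1 to compound 3 gives a 5.7-fold higher number from compound 1 to compound 3 (0.75 log units; beyond the scatter).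

Compound 4 `COC(=O)c1c(C)cccc1OC(=O)COc1cc(O)c2c(=O)cc(-c3ccccc3)oc2c1` is not yet measured. Against compound 2 the change is a group of 11 heavy atoms (9 carbon, 2 oxygen; one six-membered aromatic ring of carbon only) in place of a group of 11 heavy atoms (8 carbon, 2 oxygen, 1 chlorine; one six-membered aromatic ring of carbon only), on an oxygen next to a carbonyl group. The measured steps that bear on it are the two that also swap the aryl group on this oxygen: a 1.8-fold higher number from compound 1 to compound 2 (0.26 log units; within the scatter) lay within the scatter, while a 3.1-fold higher number from compound 2 to compound 3 (0.49 log units; beyond the scatter) was modest and weakening. Within the data shown here, no measured compound carries a methyl here, so the change has no direct precedent. A step near the scatter or a modest weakening is therefore expected, with a 1.2-fold higher number from compound 2 to compound 4 (0.08 log units; within the scatter) as the expected size. Compound 4 is estimated at 15000 nM in this assay, within 6000 nM to 40000 nM.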

Compound 4, half-maximal inhibitory concentration: 37200 nM
Beside the measured number, compound 4's estimate is 2.5-fold (0.39 log units) below it; the measured number falls inside the stated range.
By their numbers in this assay, from the lowest: compounds 1 and 2 (each within the scatter of the next); then compounds 4 and 3 (each within the scatter of the next).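

In this assay the halogen-free aryl group of compound 4 gives a 3.0-fold higher number from compound 2 to compound 4 (0.48 log units; beyond the scatter) and a 5.5-fold higher number from compound 1 to compound 4 (0.74 log units; beyond the scatter); a methyl-bearing group on this oxygen therefore does not hold the number seen with compounds 1 and 2. The comparison with the chlorine-bearing group gives a 1.0-fold lower number from compound 3 to compound 4 (0.02 log units; within the scatter), so two different aryl groups now sit together at the high end of the series, and a chlorine is not required to reach that level. No measurement on hand accounts for these steps.

The compounds shown do not separate the identity of the methyl from where it sits on the aryl ring. Also open, as far as these compounds go, is how an amine, a carboxylic acid or a longer alkyl chain on this aryl group would read in this assay.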